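The source may hold more compounds than are shown below. What is called first, only, known or untested is meant among the compounds shown, and "the series" means these compounds.

In an ADME assay on MDCKII-LE cells (Canis lupus familiaris) for permeability, read by transwell migration, in the apical to basolateral direction (a lower number here means that the compound crosses the layer more slowly, a higher number that the compound crosses the layer faster), compound 1 (`CC1(C)C[C@H](CN([C@H](CCC(F)(F)F)C(N)=O)S(=O)(=O)c2ccc(Cl)cc2)O1`) gives 18.1 10^-6 cm/s and compound 2 (`NC(=O)[C@@H](CCC(F)(F)F)N(C[C@@H]1CCCCO1)S(=O)(=O)c1ccc(Cl)cc1`) gives 15.4 10^-6 cm/s, so compound 2 has one measured neighbour and the two values lie within the scatter of each other. The step linking them is a 1.2-fold lower number from compound 1 to compound 2 (0.07 log units; within the scatter) and it puts oxan-2-yl in place of 4,4-dimethyloxetan-2-yl. Compound 3 (`NC(=O)[C@@H](CCC(F)(F)F)N(C[C@H]1CCCOC1)S(=O)(=O)c1ccc(Cl)cc1`) has yet to be measured. It differs from compound 2 by oxan-3-yl in place of oxan-2-yl on a saturated chain carbon bound to a sulfonamide nitrogen, with oxan-3-yl in place of oxan-2-yl on a saturated chain carbon bound to a sulfonamide nitrogen. For the measured compounds named here, the only measured step at this place stayed within the scatter (a 1.2-fold lower number from compound 1 to compound 2 (0.07 log units; within the scatter)), so no change beyond the scatter is expected in this assay and no direction can be favoured. The estimated step is a 1.0-fold lower number from compound 2 to compound 3 (0.01 log units; within the scatter) in this reading. For compound 3 the expected value is 15 10^-6 cm/s with an estimated range from 9 10^-6 cm/s to 24 10^-6 cm/s in this measurement.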

Compound 3, apparent permeability: 18.2 10^-6 cm/s
The estimate for compound 3 lay 1.2-fold (0.08 log units) below the measured number; measured number inside the range.
By their numbers in this assay, from the lowest: compounds 2, 1 and 3 (each within the scatter of the next).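

Putting oxan-3-yl in place of oxan-2-yl on a saturated chain carbon bound to a sulfonamide nitrogen gives a 1.2-fold higher number from compound 2 to compound 3 (0.07 log units; within the scatter) in this assay, a change that keeps the same atoms and only joins them differently. The comparison with the 4,4-dimethyloxetan-2-yl group gives a 1.0-fold higher number from compound 1 to compound 3 (0.00 log units; within the scatter), so all three ether-bearing rings at this place now read alike in this assay, whether the ring differs in its point of attachment or in its size and substitution. Nothing available offers an explanation for this flat reading.

All three groups shown are uncharged rings with one oxygen, so it remains open whether an amine or a carboxylic acid at this place would stay within the scatter. Also open, as far as these compounds go, is whether a plain cyclohexyl ring, without the oxygen, would read the same.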